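The source may hold more compounds than are shown below. What is called first, only, known or untested is meant among the compounds shown, and "the series" means these compounds.

Measured so far in a functional assay on SGC-7901 cells (Homo sapiens) for antiproliferative activity, read by MTT assay, with a stated time of 24 h; a higher number here means a weaker inhibitor, a lower number a stronger inhibitor:

compound 1 `O=C(NNc1ccccc1F)c1cccc(NS(=O)(=O)c2cnc(O)nc2O)c1` gives > 20000 nM, which is a limit of the assay and not a number.
compound 2 `O=C(NNc1ccc(F)cc1)c1cccc(NS(=O)(=O)c2cnc(O)nc2O)c1` gives > 20000 nM, again a limit of the assay.
compound 3 `O=C(NNc1ccccc1F)c1ccccc1NS(=O)(=O)c1cnc(O)nc1O` gives > 20000 nM, again a limit of the assay.

Going by the values given here, every value in the set so far sits at the limit of > 20000 nM in this assay, at which 3 of the 3 values shown sit, so no compound has yet returned a readable number. Among the compounds with values here, the one structural change that has been made twice is 4-fluorophenyl in place of 2-fluorophenyl on an amine nitrogen. Between the measured pair it produces a step that the two limits leave unreadable from compound 1 to compound 2, and with a limit at either end the size of that step cannot be read in either direction. Compound 3 carries the same sulfonamide and hydrazide parts on a different core; the difference between the cores of compound 1 and compound 3 is not broken down here.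

Compound 4 `O=C(NNc1ccc(F)cc1)c1ccccc1NS(=O)(=O)c1cnc(O)nc1O` is not yet measured in this assay. It stands to compound 3 exactly as compound 2 stands to compound 1, the same change in the same place: 4-fluorophenyl in place of 2-fluorophenyl on an amine nitrogen. The expected step from compound 3 to compound 4 is one that stays unreadable, because compound 1 and compound 2 both sit at the limit of > 20000 nM in this assay, at which 3 of the 3 values shown sit, and nothing in the set suggests a readable number. That expected step reads a step that the limit leaves unreadable from compound 3 to compound 4. Compound 4 is therefore estimated at 30000 nM in this assay, most probably reported as a limit once more, with the range 15000 nM to 100000 nM carrying that uncertainty.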

Compound 4, half-maximal inhibitory concentration: > 20000 nM
Compound 4: no number, only a limit (the forecaster's own chance of this, stated with the estimate: 85%); the middle value lies beyond the limit too.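

In this assay compound 4 gives > 20000 nM, which is a limit of the assay and not a number. No step can be read from compound 3 to compound 4, because the series still sits entirely at that limit: the limit of > 20000 nM in this assay, at which 4 of the 4 values shown sit.

The compounds shown leave open how 4-fluorophenyl and 2-fluorophenyl compare on an amine nitrogen, and whether either core can return a readable number in this assay.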